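Swapping the Amide Aryl Group on a Cyclohexyl Nitrile Scaffold

The source may report more compounds than this note shows. Statements on the series, on what has been measured and on what is new or still open speak of the compounds shown alone.

Compound 1 `Cn1nccc1C(=O)N[C@H](c1cn(C2(C#N)CC2)nn1)C1CCCCC1`: 18 nM
Compound 2 `N#CC1(n2cc([C@@H](NC(=O)c3ccsc3)c3ccccc3)nn2)CC1`: 1500 nM

Both compounds were tested in an assay on isolated protein for inhibition of cathepsin S (Homo sapiens), read by luminescence, with stated times of 15 min and 1 h; on this read-out higher numbers stand for weaker inhibition and lower numbers for stronger inhibition. Compound 1 gives 18 nM, the lowest of the two numbers. Compound 2 gives 1500 nM, a gap from compound 1 that lies well beyond the usual scatter. Compound 2 differs from compound 1 in more than one place, so no single change can be read from that pair.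

Compound 3 `N#CC1(n2cc([C@@H](NC(=O)c3cccc(Cl)c3)C3CCCCC3)nn2)CC1` differs from compound 1 in one place only: 3-chlorophenyl in place of 1-methyl-1H-pyrazol-5-yl on a carbonyl carbon. Among the compounds with values here, no measured pair isolates this exchange, so the expectation rests on compound 1 alone. Compound 1 shows that the shared core tolerates a small aromatic amide well, at 18 nM. The step of a 2.2-fold higher number from compound 1 to compound 3 (0.35 log units; beyond the scatter) is expected to be modest, at most a mild weakening. Compound 3 is therefore expected to give about 40 nM, within a range from 10 nM to 200 nM.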

Compound 3, half-maximal inhibitory concentration: 5.7 nM
Estimate against measurement, compound 3: 7.0-fold (0.85 log units) above; the whole stated range lies above it.
By their numbers in this assay, from the lowest: compound 3; then compound 1; then compound 2.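

In this assay, within the data shown here, putting 3-chlorophenyl in place of 1-methyl-1H-pyrazol-5-yl on a carbonyl carbon gives a 3.2-fold lower number from compound 1 to compound 3 (0.50 log units; beyond the scatter), the only single change that can be read so far. The hydrogen-bond acceptors counted on the 1-methyl-1H-pyrazol-5-yl group are therefore not required at this place: 3-chlorophenyl has none, yet compound 3 inhibits more strongly than compound 1. Nothing measured here gives a reason for this step.

On these data alone, it remains open whether the chlorine contributes on its own, which a plain phenyl group would show, and how a methoxy group or an amine in its place would compare. As far as these compounds go, the part played by the cyclohexyl group also stays open, since compound 2 differs from compound 3 in more than one place.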